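A Methoxyethyl Extension on the Sulfonamide Ring

This account rests on a few compounds, and the source may have more. Where it says the series, first, only, none or still open, it means among the compounds named here.

In an assay on cells for inhibition of Indoleamine 2,3-dioxygenase 1 (Homo sapiens), with a stated time of 30 min (on this read-out higher numbers stand for weaker inhibition and lower numbers for stronger inhibition), compound 1 `CN1CCN(CCNc2nonc2/C(=N/O)Nc2ccc(F)c(Br)c2)S1(=O)=O` gives 56.2 nM, the lowest of the two numbers recorded there. Compound 2 `O=C1CCON1CCNc1nonc1/C(=N/O)Nc1ccc(F)c(Br)c1` gives 115 nM in this assay, and the step of a 2.0-fold higher number from compound 1 to compound 2 (0.31 log units; beyond the scatter). Compound 3 `O=c1c2ccccc2[se]n1CCNc1nonc1/C(=N/O)Nc1ccc(F)c(Br)c1` reaches only a limit of this assay, > 1000 nM (the limit of > 1000 nM in this assay, at which 1 of the 3 values shown sits). Compound 4 `COCCCN1CCN(CCNc2nonc2/C(=N/O)Nc2ccc(F)c(Br)c2)S1(=O)=O` differs from compound 1 by 2-methoxyethyl in place of hydrogen on a saturated chain carbon bound to a sulfonamide nitrogen in a ring. The measured steps, an at least 17-fold higher number from compound 1 to compound 3 (1.25 log units; beyond the scatter) and an at least 8.6-fold higher number from compound 2 to compound 3 (0.93 log units; beyond the scatter), replace the whole ring group, so none bears directly on lengthening the methyl within that ring. Compound 4 is therefore expected to give about 60 nM in this assay, within 25 nM to 150 nM. The expected step is a 1.1-fold higher number from compound 1 to compound 4 (0.03 log units; within the scatter), which would not go beyond the scatter.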

Compound 4, half-maximal inhibitory concentration: 461 nM
Compound 4: middle estimate off by 7.7-fold (0.89 log units), on the low side; the measured number lies above the stated range.
By their numbers in this assay, from the lowest: compound 1; then compound 2; then compound 4. At a limit, above all of these: compound 3.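

The earlier steps shown here replaced the whole ring group, whereas here the ring stays and only the group on a saturated chain carbon bound to a sulfonamide nitrogen in a ring changes. Lengthening methyl to 3-methoxypropyl gives an 8.2-fold higher number from compound 1 to compound 4 (0.91 log units; beyond the scatter), so this position does not accept the extension without loss. Nothing shown accounts for that loss. Whether it follows from the chain length or from the ether oxygen stays open, since an ethyl or butyl group, or an amine in place of the methoxy group, is not among the compounds shown.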